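Methyl on the aromatic ring: effect on cytotoxicity

The source may report more compounds than this note shows. Statements on the series, on what has been measured and on what is new or still open speak of the compounds shown alone.

Measured in a functional assay on MCF7 cells (Homo sapiens) for cytotoxicity, read by MTT assay, with a stated time of 72 h; a lower number here means a stronger inhibitor, a higher number a weaker inhibitor:
- compound 1 `N/C(=N\NC(=S)N1CCCCCC1)c1ccccn1` gives 2600 nM
- compound 2 `N/C(=N\NC(=S)N1CCCCC1)c1ccccn1` gives 8500 nM
- compound 3 `Cc1cccc(/C(N)=N/NC(=S)N2CCCCCC2)n1` gives 54700 nM

Compound 1 carries a seven-membered saturated ring on the thiourea, compound 2 a six-membered one; the difference between the two cores is not broken down here. The two values show compound 2 with the higher number, beyond the scatter.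

From compound 1 to compound 3 the change is methyl in place of hydrogen on an aromatic carbon and it made a 21-fold higher number from compound 1 to compound 3 (1.32 log units; beyond the scatter).

Compound 4 `Cc1ccnc(/C(N)=N/NC(=S)N2CCCCC2)c1` is not yet measured. It differs from compound 2 by methyl in place of hydrogen on an aromatic carbon. This is the same kind of change as from compound 1 to compound 3, but not the same: in compound 3 the methyl sits next to the ring nitrogen and meta to a large group, in compound 4 it sits meta to a large group and opposite the ring nitrogen. Within the data shown here, with only one measured example of a methyl entering this ring, and that at a different place, the size of the step is uncertain.

The step is expected to run in the same direction, a weaker inhibitor, but smaller than the one seen, because a 21-fold higher number from compound 1 to compound 3 (1.32 log units; beyond the scatter) came from a methyl at a place that compound 4 does not share; the expected step is a 2.9-fold higher number from compound 2 to compound 4 (0.47 log units; beyond the scatter). Compound 4 is expected to give 25000 nM, with a range from 8000 nM to 80000 nM.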

Compound 4, half-maximal inhibitory concentration: 18800 nM
Beside the measured number, compound 4's estimate is 1.3-fold (0.12 log units) above it; low and high end bracket the measured number.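

In this assay methyl in place of hydrogen on an aromatic carbon, here opposite the ring nitrogen, gives a 2.2-fold higher number from compound 2 to compound 4 (0.34 log units; beyond the scatter), so the number rises on both cores, but the size of the step does not carry over from one core to the other: the same change on two cores in this assay, a 21-fold higher number (1.32 log units; beyond the scatter) from compound 1 to compound 3 and a 2.2-fold higher number (0.34 log units; beyond the scatter) from compound 2 to compound 4, 9.5-fold (0.98 log units) apart, beyond the scatter of two such steps

The two steps differ in two things at once, the saturated ring on the thiourea and the place of the methyl on the aromatic ring, and the pair cannot tell which of these accounts for the gap. Only the direction carries over in this series, towards a weaker inhibitor in both examples, and two examples give no rule for a methyl at any other place on this ring or on any other core.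

The compounds shown leave open how a methyl opposite the ring nitrogen behaves on the core of compound 1, a comparison that would separate the place of the methyl from the effect of the core. Also open, going by these compounds, is whether a chlorine, a methoxy group, an amine or a longer chain at these ring places follows the same direction as methyl.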